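The source may report more compounds than this note shows. Statements on the series, on what has been measured and on what is new or still open speak of the compounds shown alone.

Compound 1 `O=C(O)CCC/C=C\CC1C2CCC(O2)C1CSCC1CCCCC1` and compound 2 `O=C(O)CCC/C=C\CC1C2CCC(O2)C1CSCCOc1ccccc1` share one core and differ only at the saturated chain carbon bound to a sulfur. In a functional assay on a cell-free system (plasma) with thromboxane A2 receptor (Homo sapiens) as the target (a lower number here means a stronger inhibitor, a higher number a weaker inhibitor), compound 1 gives 20000 nM and compound 2 gives 20000 nM. The step of no change at the digits printed from compound 1 to compound 2 (within the scatter) is the sole measured one, so compound 2 stands level with compound 1. Compound 3 `O=C(O)CCC/C=C\CC1C2CCC(O2)C1CSC/C=C/c1ccccc1` is the next variation at that place: 2-phenylethenyl in place of phenoxymethyl on a saturated chain carbon bound to a sulfur. For the measured compounds named here, only the step of no change at the digits printed from compound 1 to compound 2 (within the scatter) bears on it, and it stayed within scatter, so no step beyond scatter is expected in this assay. For compound 3 the estimate is 20000 nM, range 7000 nM to 50000 nM. The expected step of no change at the digits printed from compound 2 to compound 3 (within the scatter) is thus flat.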

Compound 3, half-maximal inhibitory concentration: 86000 nM
The estimate for compound 3 lay 4.3-fold (0.63 log units) below the measured number; the whole stated range lies below it.
By their numbers in this assay, from the lowest: compounds 1 and 2 (each within the scatter of the next); then compound 3.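

In this assay, the place on a saturated chain carbon bound to a sulfur proves able to shift the number: 2-phenylethenyl in place of phenoxymethyl gives one rise (a 4.3-fold higher number from compound 2 to compound 3 (0.63 log units; beyond the scatter)), and 2-phenylethenyl in place of cyclohexyl gives another (a 4.3-fold higher number from compound 1 to compound 3 (0.63 log units; beyond the scatter)). Cyclohexyl and phenoxymethyl had not separated, so the flat reading from those two groups does not hold for every group here. Nothing on hand accounts for the rise. Open, on these data alone, is whether an amine, a carboxylic acid or a longer chain at this place would bring the number down rather than up.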